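The source may report more compounds than this note shows. Statements on the series, on what has been measured and on what is new or still open speak of the compounds shown alone.

For the measured compounds named here, compound 2, `CCN(CCN)c1ccc(Nc2cc(NC3CC3)n3ncc(C#N)c3n2)cc1NC(C)=O`, gives 2 uL/min in an ADME assay on cells (Hepatocyte, Rattus norvegicus) for metabolic stability (on this read-out lower numbers stand for slow clearance and higher numbers for fast clearance), the lowest of the two numbers measured, with compound 1, `CCN(CC)CCN(C)c1ccc(Nc2cc(NC3CC3)n3ncc(C#N)c3n2)cc1NC(C)=O`, as its only neighbour at 27 uL/min. Going by the values given here, the one measured step, a 14-fold lower number from compound 1 to compound 2 (1.13 log units; beyond the scatter), lies at the same aromatic carbon that is changed here and shows that this position can move the read-out a long way.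

Compound 3, `CC(=O)Nc1cc(Nc2cc(NC3CC3)n3ncc(C#N)c3n2)ccc1N1CC[C@H](N)C1`, is not yet measured. Compared with compound 2 it carries a group of 6 heavy atoms (4 carbon, 2 nitrogen; one five-membered non-aromatic ring with 1 hetero atom) in place of a group of 6 heavy atoms (4 carbon, 2 nitrogen; no ring), on an aromatic carbon; what leaves and what enters hold the same count of heavy atoms, donors and acceptors, so the change is smaller in kind than the one from compound 1 to compound 2.

Among the compounds with values here, no measured pair shows a chain against a ring at this position, so the direction rests only on compound 2 already standing at the lowest number seen. Compound 3 is therefore expected to stay close to compound 2, with a step of a 2.0-fold higher number from compound 2 to compound 3 (0.30 log units; within the scatter) at most toward faster clearance. The estimate for compound 3 is 4 uL/min, with a range from 1.5 uL/min to 12 uL/min.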

Compound 3, intrinsic clearance in a liver preparation (reported as CLH), per the amount of preparation that the assay uses: < 1 uL/min
Compound 3 was reported as a limit; the forecaster's own chance of this, stated with the estimate: 10%; middle value at least 4.0-fold (0.60 log units) from the limit.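

In this assay compound 3 gives < 1 uL/min as a limit of the assay and not as a number. The earlier compounds shown here held only open chains at this aromatic carbon, and 3-aminopyrrolidin-1-yl now shows that a ring here also keeps the read-out at the slow-clearance end, with an at least 27-fold lower number from compound 1 to compound 3 (1.43 log units; beyond the scatter) standing as a large step even at its floor. Against the open chain, the ring gives an at least 2.0-fold lower number from compound 2 to compound 3 (0.30 log units; that floor lies within the scatter) and so shows no rise, but how far the two stand apart cannot be read past the end of the scale, and that floor alone does not separate them: the limit of < 1 uL/min in this assay, at which 1 of the 3 values shown sits.

On these data alone, both low-clearance compounds carry a primary amine, so it remains open whether the low numbers follow that amine or the shape of the group, which a 3-(dimethylamino)pyrrolidin-1-yl group at this position could help to separate. Also open, as far as these compounds go, are a larger ring such as 4-aminopiperidin-1-yl and the mirror-image form of the 3-aminopyrrolidin-1-yl group, so neither ring size nor the defined stereocentre can yet be judged.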